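Methoxy for methylsulfonyl on the pyridyl-pyrazolol series

This account rests on a few compounds, and the source may have more. Where it says the series, first, only, none or still open, it means among the compounds named here.

Of the compounds shown here, three of the shared core have been measured in an ADME assay on WI-38 cells (Homo sapiens) for inhibition, read by CellTiter-Glo, with a stated time of 4 days; a lower number here means a stronger inhibitor of growth, a higher number a weaker inhibitor of growth. Compound 1 `Oc1cc(-c2ccccc2)nn1-c1cc(Cl)ccn1` gives > 30000 nM, a limit of the assay. Compound 2 `Oc1cc(-c2ccccc2)nn1-c1ccc(Cl)cn1` gives > 12000 nM; 19000 nM (2 entries), several entries in this assay. Compound 3 `CS(=O)(=O)c1ccc(-n2nc(-c3ccccc3)cc2O)nc1` gives > 30000 nM, again a limit of the assay and no number. Compound 3 thus stands where most of the series stands: the limit of > 30000 nM in this assay, at which 2 of the 3 values shown sit, and the repeated entries of compound 2, (the several entries of compound 2 in this assay, > 12000 nM; 19000 nM (2 entries)), show that even where a number appears it lies close to that region. For the measured compounds named here, no step between measured compounds can be counted.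

Compound 4 `COc1ccc(-n2nc(-c3ccccc3)cc2O)nc1` differs from compound 3 by methoxy in place of methylsulfonyl on an aromatic carbon. Nothing measured here ties growth inhibition to the group at that position, so the step from compound 3 to compound 4 in this assay is expected to be none beyond the scatter, with compound 4 most likely ending at a limit again; this expectation is a number no higher from compound 3 to compound 4 (the limit leaves the size open). Compound 4 is estimated at 30000 nM in this assay, within 10000 nM to 100000 nM.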

Compound 4, concentration for 50% growth inhibition: 25400 nM
Estimate against measurement, compound 4: 1.2-fold (0.07 log units) above; measured number inside the range.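

In this assay, methoxy on this aromatic carbon, two atoms from the ring nitrogen, gives a single number in compound 4, where methylsulfonyl in compound 3 gives only a limit. Going by these compounds, the change yields an at least 1.1-fold lower number from compound 3 to compound 4 (0.07 log units; that floor lies within the scatter), so the real size of the step stays unknown and no gain in growth inhibition can be claimed from it. Replacing methylsulfonyl with the smaller methoxy therefore leaves compound 4 in the region where the other compounds sit: the limit of > 30000 nM in this assay, at which 2 of the 4 values shown sit.

On these data alone, whether an amine or a carboxylic acid on the same carbon would move the number beyond the scatter stays open. As far as these compounds go, the true distance between compound 3 and compound 4 also stays open as long as compound 3 has only a limit.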